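Trimming the Alkenyl Chain on the Amide Carbonyl

The compounds below may be only part of what the source reports. "The series", "measured", "known", "first", "only" and "open" are said of these compounds alone.

Three measured compounds share one core and differ only in the group on the carbonyl carbon. Compound 1 `COc1ccc(CN(C(=O)CCl)c2cc(OC)c(OC)c(OC)c2)cc1O` carries a chloromethyl there and, in a functional assay on HCT-116 cells (Homo sapiens) for inhibition, read by MTT assay, with a stated time of 48 h (on this read-out lower numbers stand for stronger inhibition and higher numbers for weaker inhibition), compound 1 gives 250 nM. Compound 2 `COc1ccc(CN(C(=O)C=C(C)C)c2cc(OC)c(OC)c(OC)c2)cc1O` carries a 2-methylprop-1-en-1-yl and gives 290 nM; the step of a 1.2-fold higher number from compound 1 to compound 2 (0.06 log units; within the scatter) is within the scatter. Compound 3 `C/C=C/C(=O)N(Cc1ccc(OC)c(O)c1)c1cc(OC)c(OC)c(OC)c1` carries a prop-1-en-1-yl and gives 55 nM, the lowest of the three numbers: a 4.5-fold lower number from compound 1 to compound 3 (0.66 log units; beyond the scatter) and a 5.3-fold lower number from compound 2 to compound 3 (0.72 log units; beyond the scatter) both lie beyond the scatter, so compound 3 is the most potent compound measured. Compound 4 `C=CC(=O)N(Cc1ccc(OC)c(O)c1)c1cc(OC)c(OC)c(OC)c1` differs from compound 3 in one place: vinyl in place of prop-1-en-1-yl on a carbonyl carbon. The step that bears most directly is a 5.3-fold lower number from compound 2 to compound 3 (0.72 log units; beyond the scatter), where prop-1-en-1-yl in place of 2-methylprop-1-en-1-yl lowered the number modestly; a 4.5-fold lower number from compound 1 to compound 3 (0.66 log units; beyond the scatter) points the same way. Whether a further shortening of the alkenyl group repeats this is uncertain, so a small lowering or no change beyond the scatter is expected. Compound 4 is estimated at 40 nM, with a range from 15 nM to 120 nM. The expected step is a 1.4-fold lower number from compound 3 to compound 4 (0.14 log units; within the scatter).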

Compound 4, half-maximal inhibitory concentration: 98 nM
The estimate for compound 4 lay 2.5-fold (0.39 log units) below the measured number, and the stated range covers the measured number.
By their numbers in this assay, from the lowest: compounds 3 and 4 (each within the scatter of the next); then compounds 1 and 2 (each within the scatter of the next).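

In this assay, the further shortening from prop-1-en-1-yl to vinyl on the carbonyl carbon gave no difference that can be read (a 1.8-fold higher number from compound 3 to compound 4 (0.25 log units; within the scatter)), so the lowering seen on going from 2-methylprop-1-en-1-yl to prop-1-en-1-yl did not continue beyond the scatter. Vinyl still stands apart from the two other groups (a 3.0-fold lower number from compound 2 to compound 4 (0.47 log units; beyond the scatter); a 2.6-fold lower number from compound 1 to compound 4 (0.41 log units; beyond the scatter)), so compound 3 no longer stands alone and the four compounds fall into two groups: compounds 3 and 4, then compounds 1 and 2. An alkenyl group alone does not place a compound in the first group, as compound 2 goes against that.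

The data shown offer nothing that explains these differences. On these data alone, it remains open whether an ethyl group, a longer chain or a dimethylaminomethyl group on this carbonyl carbon would sit with compounds 3 and 4.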